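The compounds below may be only part of what the source reports. "The series", "measured", "known", "first", "only" and "open" are said of these compounds alone.

In a functional assay on A549 cells (Homo sapiens) for antiproliferative activity, read by MTT assay, with a stated time of 72 h (on this read-out lower numbers stand for stronger inhibition and higher numbers for weaker inhibition), three compounds have been measured. Compound 1 `CC(Nc1nc(N)nc2ccc(-c3cnn(C4CCNCC4)c3)cc12)c1c(Cl)ccc(F)c1Cl` gives 8800 nM, the lowest of the three numbers. Compound 2 `CC(Oc1nc(N)nc2ccc(-c3cnn(C4CCNCC4)c3)cc12)c1c(Cl)ccc(F)c1Cl` gives 9490 nM, which lies within the scatter of compound 1. Compound 3 `Cn1cc(-c2ccc3ncnc(Oc4ccc5ncccc5c4)c3c2)cn1` gives 26600 nM, beyond the scatter from compound 1. Compound 4 `CC(Nc1nc(N)nc2ccc(-c3cnn(C)c3)cc12)c1c(Cl)ccc(F)c1Cl` has not yet been measured. It differs from compound 1 by methyl in place of piperidin-4-yl on an aromatic nitrogen. Going by the values given here, no step between measured compounds that differ in this one place is known, so the data give no direct guide to its size. Compound 4 is expected to sit somewhat weaker than compound 1, a step of a 2.3-fold higher number from compound 1 to compound 4 (0.36 log units; beyond the scatter), though this is uncertain. Compound 4 is therefore estimated at 20000 nM, with a range from 7000 nM to 60000 nM.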

Compound 4, half-maximal inhibitory concentration: > 100000 nM
Compound 4 ended at the assay's limit (the forecaster's own chance of this, stated with the estimate: 15%); middle value at least 5.0-fold (0.69 log units) away from the limit.
By their numbers in this assay, from the lowest: compounds 1 and 2 (each within the scatter of the next); then compound 3. At a limit, above all of these: compound 4.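

The value of compound 4 in this assay is a limit of the assay and not a number: the limit of > 100000 nM in this assay, at which 1 of the 4 values shown sits.

Methyl in place of piperidin-4-yl on the aromatic nitrogen gives an at least 11-fold higher number from compound 1 to compound 4 (1.05 log units; beyond the scatter), the first step shown at this position. It shows that the antiproliferative activity of compound 1 depends on the group at this nitrogen, and that methyl does not retain it.

From the compounds shown here alone, what remains open is which part of piperidin-4-yl matters, the ring itself or its ring nitrogen. A cyclohexyl ring or an aminoethyl chain on the same nitrogen would separate the two.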